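Working notes: dimethylamino in place of piperidin-1-yl

The compounds below may be only part of what the source reports. "The series", "measured", "known", "first", "only" and "open" are said of these compounds alone.

Measured in a functional assay on A549 cells (Homo sapiens) for cytotoxicity, read by MTT assay, with a stated time of 72 h; a higher number here means a weaker inhibitor, a lower number a stronger inhibitor
- compound 1 `O=C1c2c[n+]([O-])c3ccccc3c2C(=O)c2c1c1ccccc1n2CCCCN1CCNCC1` gives 540 nM
- compound 2 `CCCCN1CCN(CCCCn2c3c(c4ccccc42)C(=O)c2c[n+]([O-])c4ccccc4c2C3=O)CC1` gives 550 nM
- compound 3 `O=C1c2c[n+]([O-])c3ccccc3c2C(=O)c2c1c1ccccc1n2CCCCN1CCCCC1` gives 150 nM

Compound 3 has the lowest of the three numbers in this assay, and its gaps to both others lie beyond the scatter. The next change is dimethylamino in place of piperidin-1-yl on a saturated chain carbon, four bonds along the chain from an aromatic nitrogen, which gives compound 4 `CN(C)CCCCn1c2c(c3ccccc31)C(=O)c1c[n+]([O-])c3ccccc3c1C2=O`, not yet measured.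

Among the compounds with values here, three measured steps bear on this change. Two of them alter the amine at the same place on the chain: a 3.6-fold lower number from compound 1 to compound 3 (0.56 log units; beyond the scatter) and a 3.7-fold lower number from compound 2 to compound 3 (0.56 log units; beyond the scatter). Both are modest and beyond the scatter, so a change of group at this place has moved the number in this series. The third, a 1.0-fold higher number from compound 1 to compound 2 (0.01 log units; within the scatter), lies within the scatter and shows no measurable effect of the added butyl. Within the data shown here, all three measured compounds carry a ring at this place, and no measured compound has an open-chain amine there, so the direction is only weakly supported. Among the measured compounds shown here, with compound 3 at 150 nM as the lowest number so far, a modest step towards a higher number is expected, though a step within the scatter remains possible. The expected step is a 1.7-fold higher number from compound 3 to compound 4 (0.22 log units; within the scatter). Compound 4 is estimated at 250 nM, with an expected range of 100 nM to 600 nM.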

Compound 4, half-maximal inhibitory concentration: 310 nM
Compound 4: middle estimate off by 1.2-fold (0.09 log units), on the low side, within the range that was stated.
By their numbers in this assay, from the lowest: compound 3; then compounds 4, 1 and 2 (each within the scatter of the next).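

Notes on the amine at the end of the chain: in this assay, the earlier compounds carried only rings at this place, on a saturated chain carbon, four bonds along the chain from an aromatic nitrogen, and the open-chain dimethylamino now shows that replacing piperidin-1-yl costs a modest amount, with a 2.1-fold higher number from compound 3 to compound 4 (0.32 log units; beyond the scatter) leaving compound 3 as the strongest of the four. Set against the two piperazine compounds, a 1.8-fold lower number from compound 2 to compound 4 (0.25 log units; within the scatter) and a 1.7-fold lower number from compound 1 to compound 4 (0.24 log units; within the scatter) both stay within the scatter, so having a ring at this place does not by itself set the number: compounds 1 and 2 carry rings yet cannot be told apart from the ringless compound 4, and only piperidin-1-yl stands apart. Nothing at hand accounts for why piperidin-1-yl stands apart from the other three amines.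

Going by these compounds, it remains open whether diethylamino, pyrrolidin-1-yl or morpholin-4-yl at this place would group with compound 3 or with compounds 1, 2 and 4. Also open, on these data alone, is whether the gap between piperidin-1-yl and dimethylamino holds on a shorter or a longer chain.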